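The source may hold more compounds than are shown below. What is called first, only, known or untested is meant among the compounds shown, and "the series" means these compounds.

Values in an ADME assay on MT4 cells (Homo sapiens) for cytotoxicity, read by MTT assay, with a stated time of 4 days (on this read-out lower numbers stand for higher toxicity in this test and higher numbers for lower toxicity in this test), for the three measured members of the series:
compound 1 `Cc1cccc(Oc2nc(Nc3ccc(C#N)cc3)nc3ccccc23)c1` gives 355000 nM
compound 2 `COc1ccccc1Oc1nc(Nc2ccc(C#N)cc2)nc2ccccc12` gives 150000 nM
compound 3 `CCCOc1cc(C#N)cc(OCC)c1Oc1nc(Nc2ccc(C#N)cc2)nc2ccccc12` gives 123000 nM

Compound 2 stands second highest of the three numbers. Among the measured compounds shown here, its nearest neighbour is compound 3, whose number lies within the scatter of that of compound 2, so the two are not separated here; the only separated number is that of compound 1, reached by a 2.4-fold lower number from compound 1 to compound 2 (0.37 log units; beyond the scatter).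

The next compound, compound 4 `N#Cc1ccc(Nc2nc(Oc3ccc(Cl)cc3)c3ccccc3n2)cc1`, differs from compound 2 in one place: 4-chlorophenyl in place of 2-methoxyphenyl on an oxygen on an aromatic ring. For the measured compounds named here, the only measured step that touches the same place is a 2.4-fold lower number from compound 1 to compound 2 (0.37 log units; beyond the scatter), and it was modest. Going by the values given here, no measured compound carries a 4-chlorophenyl on that oxygen, and no measured step pairs a 2-methoxyphenyl with a 4-chlorophenyl, so the direction of this change is not fixed by the data; the one relevant step only sets the scale at modest. The whole measured range is narrow, from compound 3 up to compound 1. The expected step is therefore small, within the scatter, with the direction undecided: a 1.1-fold higher number from compound 2 to compound 4 (0.03 log units; within the scatter). Compound 4 is accordingly estimated at 160000 nM in this assay, with a range of 60000 nM to 400000 nM.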

Compound 4, half-maximal cytotoxic concentration: 198000 nM
Beside the measured number, compound 4's estimate is 1.2-fold (0.09 log units) below it, and the stated range covers the measured number.
By their numbers in this assay, from the lowest: compounds 3, 2, 4 and 1 (each within the scatter of the next, the first and the last beyond it).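

In this assay, among the compounds shown here, 4-chlorophenyl is the first group on this oxygen to carry chlorine, and the change from 2-methoxyphenyl gives a 1.3-fold higher number from compound 2 to compound 4 (0.12 log units; within the scatter). Set against 3-methylphenyl, the same group gives a 1.8-fold lower number from compound 1 to compound 4 (0.25 log units; within the scatter), so compound 4 is separated from neither of the two compounds that differ from it at this position, although those two are separated from each other by a modest step. For the compounds shown here, the three aryl groups compared here therefore span only that modest step, and the swap of the methoxy-bearing ring for the chlorine-bearing one produces no separated change; no supporting data are available to explain this result.

As far as these compounds go, whether this narrow span holds for other kinds of group stays open: a carboxylic acid or an amine on the aryl ring, or a saturated ring such as cyclohexyl in its place, could behave differently. From the compounds shown here alone, it is also open whether the same tolerance would hold for the 4-chlorophenyl group on compound 3's more heavily substituted pattern, or with an amine nitrogen in place of the oxygen.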